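The compounds below may be only part of what the source reports. "The series", "measured", "known", "first", "only" and "open" are said of these compounds alone.

Measured in a functional assay (Nicotiana tabacum); on this read-out lower numbers stand for stronger inhibition and higher numbers for weaker inhibition:
- compound 1 `CCCCNc1nc(SC)nc2ncccc12` gives 270 nM
- compound 2 `CSc1nc(NCC(C)C)c2cccnc2n1` gives 540 nM

With only these two numbers in hand, compound 2 stands within the scatter of compound 1, so the pair cannot be told apart. Compound 3 `CCC(CC)Nc1nc(SC)nc2ncccc12` has not yet been measured. It departs from compound 2 by the change (pentan-3-yl in place of isobutyl on a nitrogen on an aromatic ring), with pentan-3-yl in place of isobutyl on a nitrogen on an aromatic ring. For the measured compounds named here, the only measured step, a 2.0-fold higher number from compound 1 to compound 2 (0.30 log units; within the scatter), also alters this chain and stays within the scatter. Going by the values given here, no measured compound carries pentan-3-yl, so that step offers only loose guidance. The expected change is therefore small, with no direction beyond the scatter: the estimate is a 1.2-fold lower number from compound 2 to compound 3 (0.08 log units; within the scatter) in this assay. For compound 3 the estimated value is 450 nM, with an expected range from 150 nM to 1400 nM.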

Compound 3, half-maximal inhibitory concentration: 2720 nM
Compound 3: middle estimate off by 6.0-fold (0.78 log units), on the low side, outside the stated range (above it).
By their numbers in this assay, from the lowest: compounds 1 and 2 (each within the scatter of the next); then compound 3.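

In this assay, pentan-3-yl on a nitrogen on an aromatic ring gives a 5.0-fold higher number from compound 2 to compound 3 (0.70 log units; beyond the scatter) and a 10-fold higher number from compound 1 to compound 3 (1.00 log units; beyond the scatter), so this position is not indifferent to the alkyl group it carries. Butyl and isobutyl could not be told apart, but both steps to pentan-3-yl lie beyond the scatter and go toward weaker inhibition, even though pentan-3-yl has only one more carbon than isobutyl. No measurement at hand accounts for this difference.

Going by these compounds, it remains open whether the weaker inhibition is particular to pentan-3-yl or extends to other groups at this position, such as cyclopentyl or tert-butyl. The compounds shown also leave open how a longer straight chain such as hexyl would compare with butyl.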